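A few compounds are considered here, and "the series" means these few. Any claim that something is new, unique, unknown or untested is made for them only; others in the source may bear on it.

Measured compounds in this study:

- compound 1 `CCCc1ccc(C(=O)Nc2cc3nc(C4CCCCC4)[nH]c3cc2N(C)C)cc1` — > 100 ug/mL
- compound 2 `CCCc1ccc(C(=O)Nc2cc3nc(C4CCCCC4)[nH]c3cc2N(CC)CC)cc1` — "not determined" (no result reported)
- compound 3 `CCN(CC)c1cc2[nH]c(C3CCCCC3)nc2cc1NC(=O)c1ccc(OC(F)(F)F)cc1` — > 100 ug/mL

These three compounds were tested for how strongly they harm cultured cells in an ADME assay on Vero cells (Chlorocebus sabaeus) for cytotoxicity, read by resazurin assay, with a stated time of 3 days; on this read-out higher numbers stand for weaker inhibition and lower numbers for stronger inhibition. For compound 1 the result is not a number but a limit of the assay: compound 1 reached > 100 ug/mL, meaning no half-maximal effect was seen within the range tested. Compound 3 sits at the same kind of limit, with > 100 ug/mL. For compound 2 no result was reported, "not determined" (no result reported). So compound 1 stands at the limit of > 100 ug/mL in this assay, at which 2 of the 3 values shown sit, with nothing placing it either above or below compound 3, and no finished comparison between any two measured compounds exists.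

Compound 4 `CCCCCC(=O)Nc1cc2nc(C3CCCCC3)[nH]c2cc1N(C)C` has not yet been measured in this assay. It differs from compound 1 in one place: pentyl in place of 4-propylphenyl on a carbonyl carbon. No comparable change between two measured compounds is available to show how this assay responds to such a swap. Given that compound 1 itself shows only a limit, the expectation for compound 4 in this assay is a step of a number no higher from compound 1 to compound 4 (the limit leaves the size open), that is, no change beyond the scatter. The estimated value for compound 4 is therefore 100 ug/mL, expected to fall between 50 ug/mL and 200 ug/mL, and most likely to be reported again as a limit rather than a number.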

Compound 4, half-maximal inhibitory concentration: > 100 ug/mL
Compound 4 ended at the assay's limit; the forecaster's own chance of this, stated with the estimate: 70%; the middle value lies on the limit itself.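

With pentyl in place of 4-propylphenyl on a carbonyl carbon, no step can be read in this assay, because compound 1 and compound 4 both give a limit of the assay rather than a number: the limit of > 100 ug/mL in this assay, at which 3 of the 4 values shown sit.

The compounds shown leave open what concentration of compound 1 or compound 4 would reach a half-maximal effect, and so whether this swap changes anything in this assay.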